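The compounds below may be only part of what the source reports. "The series", "measured", "known", "first", "only" and "open" are said of these compounds alone.

Values so far in a physicochemical assay for lipophilicity, measured as octanol-water partition, at pH 7.4; a lower number here means a more polar compound, a higher number a more lipophilic compound 
- compound 1 `CC(C)c1noc(N2CCC(Oc3cc(N4CCc5cc(C6CCCCC6=O)ccc54)ncn3)CC2)n1` gives 4.7 
- compound 2 `CC(C)c1noc(N2CCC(Oc3cc(N4CCc5cc(N6CCCS6(=O)=O)ccc54)ncn3)CC2)n1` gives 3.2 

For the measured compounds named here, the only measured step reads a number 1.50 log units lower from compound 1 to compound 2 (beyond the scatter) and leaves compound 2 with the lower of the two numbers. Compound 3 `CC(C)c1noc(N2CCC(Oc3cc(N4CCc5cc(N6CCCC6=O)ccc54)ncn3)CC2)n1` has not yet been measured. Its change from compound 2 is a group of 6 heavy atoms (4 carbon, 1 nitrogen, 1 oxygen; one five-membered non-aromatic ring with 1 hetero atom) in place of a group of 7 heavy atoms (3 carbon, 1 nitrogen, 2 oxygen, 1 sulfur; one five-membered non-aromatic ring with 2 hetero atoms), on an aromatic carbon and the entering group is 2-oxopyrrolidin-1-yl. Going by the values given here, no measured step exchanges these two groups directly, so the one large step bears only in part. It brought in the group that compound 3 gives up, but the group it replaced had a six-membered non-aromatic ring of carbon only. The 2-oxopyrrolidin-1-yl group instead has a five-membered non-aromatic ring with a hetero atom, as does the group that leaves. The expectation therefore starts from compound 2 at 3.2 and not from compound 1 at 4.7 as a reference. In this assay the expected step is a number 0.10 log units higher from compound 2 to compound 3 (within the scatter) and it is estimated to be far smaller than the measured one. In this assay compound 3 is estimated to give 3.3 with an expected range of 2.8 to 3.8 as its bounds.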

Compound 3, distribution coefficient: 3.7
Compound 3: middle estimate off by 0.40 log units, on the low side; measured number inside the range.
By their numbers in this assay, from the lowest: compound 2; then compound 3; then compound 1.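

In this assay, two groups that each carry a five-membered non-aromatic ring with hetero atoms can now be compared at this aromatic carbon, and a number 0.50 log units higher from compound 2 to compound 3 (beyond the scatter) shows that sharing this ring size does not make them interchangeable here. The 2-oxopyrrolidin-1-yl group also stands apart from 2-oxocyclohexyl, as a number 1.00 log units lower from compound 1 to compound 3 (beyond the scatter) shows, which places compound 3 between the two earlier compounds and gives this single position three distinct readings, each step beyond the scatter. No measured finding on these groups accounts for the size of either step, and their origin remains unassigned.

The compounds shown leave open how an open-chain acetamide or a morpholine ring would read at this aromatic carbon, since all three groups here are ring systems bearing a sulfonyl or carbonyl unit. They also leave open whether the order of these three groups would hold with a change elsewhere in the shared core, as every step shown sits at this one place.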